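Notes on a ring-amine substituent change

This account rests on a few compounds, and the source may have more. Where it says the series, first, only, none or still open, it means among the compounds named here.

Measured so far:
compound 1, `CN1C[C@@H](C(=O)c2ccccc2Cl)[C@H](c2ccc(Cl)cc2)C1`, in an assay for inhibition of Norepinephrine transporter (Rattus norvegicus) (a lower number here means a stronger inhibitor, a higher number a weaker inhibitor), compound 1 gives 69 nM
compound 2, `CN1C[C@@H](C(=O)c2ccccn2)[C@H](c2ccccc2)C1`, in this assay compound 2 gives 44 nM

Compound 2 shows the smaller of the two numbers, but the gap to compound 1 lies within the scatter, so the two count as equal here. Compound 3, `O=C(c1ccccn1)[C@@H]1CN(c2ccccc2)C[C@H]1c1ccccc1`, differs from compound 2 in one place: phenyl in place of methyl on an amine nitrogen in a ring. Going by the values given here, no measured pair shows this step, so its size cannot be read from these data. The expectation is that the number moves upward, toward weaker inhibition, and by more than the scatter. For compound 3 the expected value in this assay is 400 nM, with a range from 80 nM to 2000 nM. The step this estimate implies, a 9.1-fold higher number from compound 2 to compound 3 (0.96 log units; beyond the scatter), is expected to exceed the scatter clearly; a measurement will settle it.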

Compound 3, inhibition constant: > 10000 nM
Compound 3: no number, only a limit; the forecaster's own chance of this, stated with the estimate: 10%; middle value at least 25-fold (1.39 log units) from the limit.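

In this assay compound 3 carries a limit and not a number: the limit of > 10000 nM in this assay, at which 1 of the 3 values shown sits. Phenyl in place of methyl on the amine nitrogen in the ring gives an at least 220-fold higher number from compound 2 to compound 3 (2.35 log units; beyond the scatter), so the true size of this step is bounded on one side only. Going by these compounds alone, this is the first reading of a change at this position, and it shows that the position does not accept every group: with the rest of the structure unchanged, activity in this assay falls out of the measurable range once phenyl replaces methyl.

The compounds shown leave open how a hydrogen, an ethyl or a benzyl group on this nitrogen would read, so it remains unclear whether the drop belongs to phenyl alone or to other groups as well. Going by these compounds, whether the same step on the core of compound 1 would read alike also remains open.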